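Swapping the thiazole for a pyrimidine: expected cytotoxicity

This account rests on a few compounds, and the source may have more. Where it says the series, first, only, none or still open, it means among the compounds named here.

Compound 1 `CC(C)=CCOc1cccc(Nc2nccs2)c1` gives 23000 nM in a functional assay on MT2 cells (Homo sapiens) for cytotoxicity, read by MTT assay; a lower number here means that less compound is tolerated, a higher number that more compound is tolerated.
Compound 2 `CCCc1ccc(Nc2nccs2)cc1OCC=C(C)C` gives 23000 nM in this assay.
Compound 3 `CC(C)=CCOc1cc(Nc2nccs2)ccc1C(C)C` gives 31000 nM in this assay.

Compound 1 stands level with compound 2, the two together giving the lowest numbers of the three, and its gap to compound 3 is a 1.3-fold higher number from compound 1 to compound 3 (0.13 log units; within the scatter). Compound 4 `CC(C)=CCOc1cccc(Nc2ncccn2)c1` differs from compound 1 by pyrimidin-2-yl in place of 1,3-thiazol-2-yl on a nitrogen on an aromatic ring. For the measured compounds named here, none of the measured steps touches this part of the molecule: no change at the digits printed from compound 1 to compound 2 (within the scatter) and a 1.3-fold higher number from compound 2 to compound 3 (0.13 log units; within the scatter) both concern groups on an aromatic carbon and all stay within the scatter. With the tolerated concentration so flat across these three compounds, the step of a 1.1-fold higher number from compound 1 to compound 4 (0.04 log units; within the scatter) is expected to be small. Compound 4 is therefore estimated at 25000 nM, within the range 10000 nM to 60000 nM.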

Compound 4, half-maximal cytotoxic concentration: > 100000 nM
Compound 4: a limit, no number; the forecaster's own chance of this, stated with the estimate: 15%; middle value at least 4.0-fold (0.60 log units) away from the limit.
By their numbers in this assay, from the lowest: compounds 1, 2 and 3 (each within the scatter of the next). At a limit, above all of these: compound 4.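

Changing the group on the nitrogen does what the changes on the aromatic carbon did not: pyrimidin-2-yl in place of 1,3-thiazol-2-yl gives an at least 4.3-fold higher number from compound 1 to compound 4 (0.63 log units; beyond the scatter). In this assay compound 4 gives > 100000 nM, which is a limit and not a number. This is the first change among these compounds to move the tolerated concentration beyond the scatter, and the full size of the step stays unknown: the limit of > 100000 nM in this assay, at which 1 of the 4 values shown sits.

As far as these compounds go, what remains open is whether the larger ring or the second ring nitrogen of pyrimidin-2-yl accounts for this step. A phenyl or pyridin-2-yl group on the same nitrogen would help to separate the two.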